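Mirror-Image Pair on a Histone Deacetylase Read-Out

The compounds below may be only part of what the source reports. "The series", "measured", "known", "first", "only" and "open" are said of these compounds alone.

Compound 1 `Nc1ccccc1NC(=O)/C=C/c1cn([C@H]2C[C@@H](C(=O)O)N(CCCc3ccccc3)C2)nn1` and compound 2 `Nc1ccccc1NC(=O)/C=C/c1cn([C@H]2C[C@@H](CO)N(CCCc3ccccc3)C2)nn1` share one core and differ only at one saturated ring carbon. In an assay on cells for inhibition of histone deacetylase 11 (Homo sapiens), read by fluorescence, with stated times of 3 h and 30 min, tested at 2 uM, in the presence of a further agent that is not named here (a lower number here means less inhibition, a higher number more inhibition at the concentration tested (going by the name of the read-out)), compound 1 gives < 10%, which is a limit of the assay rather than a number. Compound 2 gives 19% in this assay. The step of a number at least 9 percentage points higher from compound 1 to compound 2 (that floor lies within the scatter) comes from hydroxymethyl in place of carboxy on a saturated ring carbon, and its floor lies within the scatter. Going by the values given here, compound 2 thus stands as the only compound with a number, the other value being a limit (the limit of < 10% in this assay, at which 1 of the 2 values shown sits).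

Compound 3 `Nc1ccccc1NC(=O)/C=C/c1cn([C@@H]2C[C@H](CO)N(CCCc3ccccc3)C2)nn1` is the next move: the two compounds have the same atoms and bonds and differ only in configuration as drawn: 2 of 3 stereo elements differ; a stereocentre at a saturated ring carbon is drawn S in compound 2 and R in compound 3; a stereocentre at a saturated ring carbon is drawn S in compound 2 and R in compound 3. Among the compounds with values here, no measured step turns on configuration, so none bears directly on this change; the single measured step, from a change of group, was itself modest. The expectation for compound 3 in this assay is therefore a value close to that of compound 2, with no shift beyond the scatter and a real chance that only a limit is reported. Compound 3 is expected at 12%, from 0% to 28%, meaning an expected step of a number 7 percentage points lower from compound 2 to compound 3 (within the scatter) that stays within the scatter.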

Compound 3, a percentage reported as inhibition, at one concentration (the size of the read-out at that concentration, not a potency): 12%
For compound 3 middle estimate and measured number coincide at the digits printed; measured number inside the range.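

Turning both stereocentres at the saturated ring carbons from S to R, while every atom and bond stays the same, gives a number 7 percentage points lower from compound 2 to compound 3 (within the scatter). Going by these compounds alone, the earlier compounds offered only a change of group, so this pair is the first view of configuration at these two ring carbons, and in this assay it separates the two drawn forms by no more than ordinary repeat measurements would. Whatever this pair says therefore concerns configuration alone, with no change of group mixed in: the fact that compounds 2 and 3 differ only in the configuration as drawn

The compounds shown leave open whether the two stereocentres matter separately, since both differ together here, and whether a form with only one of them turned would read the same way, or whether configuration would count for more at another concentration or on another histone deacetylase. They also leave open how an amine or a methyl ester would read in place of the hydroxymethyl group, and whether the carboxy group would read differently in the configuration drawn for compound 3.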